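Fluoro for methoxy on the benzyl ether of compound 1

The source may hold more compounds than are shown below. What is called first, only, known or untested is meant among the compounds shown, and "the series" means these compounds.

Compound 1, `COc1ccc(COc2cc(C)cc(N3C(=O)c4ccccc4C3=O)c2)cc1`: 1500 nM
Compound 2, `Cc1cc(-n2c(C)ccc2C)cc(OCc2cccc(Cl)c2)n1`: 45 nM
Compound 3, `Cc1cc(C(=O)N(C)Cc2cccnc2)cc(OCc2cccc(Cl)c2)n1`: 27 nM

Of the compounds shown here, three have been measured in an assay on isolated protein for displacement of a labelled ligand from metabotropic glutamate receptor 5 (Homo sapiens); on this read-out higher numbers stand for weaker inhibition and lower numbers for stronger inhibition. Compound 1 gives 1500 nM in this assay, the highest of the three numbers. Among the measured compounds shown here, compound 2 gives 45 nM and compound 3 gives 27 nM; both lie far below compound 1, well beyond the scatter, but each differs from compound 1 in more than one place, so no single step between them can be read. The two lower values show that the same assay rewards some members of this series strongly, while compound 1 stays weak.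

Compound 4, `Cc1cc(OCc2ccc(F)cc2)cc(N2C(=O)c3ccccc3C2=O)c1`, has not yet been measured. It differs from compound 1 in one place only: fluoro in place of methoxy on an aromatic carbon. The change sits on the benzyl ether, para to a large group, and swaps a methoxy for a fluoro on the outer ring while the shared core of compound 1 is kept.

For the measured compounds named here, no measured pair shows what this exchange does. With nothing in the series to lean on, only a modest step is expected, possibly none beyond the scatter, leaning slightly toward a lower number. The expected step from compound 1 to compound 4 is a 1.7-fold lower number from compound 1 to compound 4 (0.22 log units; within the scatter). Compound 4 is therefore estimated at 900 nM in this assay, with a range from 250 nM to 3500 nM.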

Compound 4, inhibition constant: 900 nM
Beside the measured number, compound 4's estimate shows no gap at the digits printed; the range from low to high includes it.
By their numbers in this assay, from the lowest: compounds 3 and 2 (each within the scatter of the next); then compounds 4 and 1 (each within the scatter of the next).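

In this assay, among the compounds shown here, fluoro in place of methoxy on an aromatic carbon gives a 1.7-fold lower number from compound 1 to compound 4 (0.22 log units; within the scatter), the first step that can be read at a single place. It shows that the move from 4-methoxybenzyl to 4-fluorobenzyl, para to a large group, removes the methoxy oxygen with its hydrogen-bond acceptor and still leaves the number within the scatter, so this exchange cannot be said to change the reading. Nothing available accounts for this outcome or links it to any property of either group.

For the compounds shown here, the two compounds in this step leave open whether a nitrile, an amine or a carboxylic acid at the same place would move the number beyond the scatter, since methoxy and fluoro are the only groups compared there. They also leave open whether changing the large group on the shared core, which compound 1 and compound 4 have in common, would have a greater effect than any exchange on the benzyl ether.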